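Fluoro to chloro exchange in a serotonin receptor agonist series

This account rests on a few compounds, and the source may have more. Where it says the series, first, only, none or still open, it means among the compounds named here.

Measured compounds:
- compound 1, `Cc1ccc(-c2n[nH]c3c2CCNCC3)cc1`: compound 1 gives 50.9% in a functional assay on cells for agonist activity at 5-hydroxytryptamine receptor 7 (Homo sapiens), read by a luciferase reporter and beta-arrestin recruitment, with a stated time of 22 h; on this read-out higher numbers stand for larger maximal responses and lower numbers for smaller maximal responses 
- compound 2, `Fc1ccc(-c2n[nH]c3c2CCNCC3)cc1`: compound 2 gives 53.9% in this assay 
- compound 3, `Cc1ccc(-c2noc3c2CCNCC3)cc1`: compound 3 gives 40.3% in this assay 

Compound 2 and compound 1 lie within the scatter of each other on the numbers shown; compound 3, which differs in the core rather than on the aryl group, sits beyond the scatter below both. Within the data shown here, the only step that touches the aryl substituent is a number 3 percentage points higher from compound 1 to compound 2 (within the scatter), which stays within the scatter.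

Compound 4, `Clc1ccc(-c2n[nH]c3c2CCNCC3)cc1`, has not been measured in this assay. It differs from compound 2 as follows: chloro in place of fluoro on an aromatic carbon. Among the measured compounds shown here, no measured pair shows a halogen replaced by another halogen, so the step from compound 1 to compound 2 is the nearest guide, and it points to no change beyond the scatter. The expected step is therefore a number 0.9 percentage points lower from compound 2 to compound 4 (within the scatter). For compound 4 the estimate in this assay is 53%, with a range from 41% to 65%.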

Compound 4, largest response reached (Emax), in percent of the reference or control that the assay uses: 62.8%
Compound 4: the middle estimate sits 9.8 percentage points below what was measured; the range from low to high includes it.
By their numbers in this assay, from the lowest: compound 3; then compounds 1, 2 and 4 (each within the scatter of the next, the first and the last beyond it).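

In this assay, chloro in place of fluoro on the aromatic carbon para to a large group gives a number 8.9 percentage points higher from compound 2 to compound 4 (within the scatter), so the two halogens are not told apart at this position. Chloro in place of methyl on the same carbon gives a number 11.9 percentage points higher from compound 1 to compound 4 (beyond the scatter), the first aryl substituent exchange to pass the scatter, though only modestly, while fluoro in place of methyl gives a number 3 percentage points higher from compound 1 to compound 2 (within the scatter). Nothing available accounts for the difference between these substituents.

The compounds shown leave open how a bromo or methoxy group would read at this position. They also leave open whether chloro in place of methyl gives a comparable step on the core of compound 3.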